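One aromatic group exchanged on a shared core

The source may hold more compounds than are shown below. What is called first, only, known or untested is meant among the compounds shown, and "the series" means these compounds.

Compound 1 `CC1(C)CCC[C@]2(C)[C@@H](CC[C@@](C)(O)/C=C/c3cncc4ccccc34)[C@](C)(O)CC[C@@H]12`: 46000 nM
Compound 2 `COc1cccc(OC)c1/C=C/[C@](C)(O)CC[C@@H]1[C@@]2(C)CCCC(C)(C)[C@@H]2CC[C@@]1(C)O`: 48200 nM

Going by the values given here, in a functional assay on HeLa cells (Homo sapiens) for cytotoxicity, read by MTT assay, with a stated time of 48 h (on this read-out higher numbers stand for weaker inhibition and lower numbers for stronger inhibition), compound 2 gives 48200 nM, which lies within the scatter of the only other measured value. Compound 3 `Cc1cccc(/C=C/[C@](C)(O)CC[C@@H]2[C@@]3(C)CCCC(C)(C)[C@@H]3CC[C@@]2(C)O)c1C` has not yet been measured. It carries 2,3-dimethylphenyl in place of 2,6-dimethoxyphenyl on a double-bonded chain carbon bound to a double-bonded chain carbon. Among the compounds with values here, the only measured step that bears on this exchange sits at the same place and leads to compound 2: a 1.0-fold higher number from compound 1 to compound 2 (0.02 log units; within the scatter), within the scatter. One step is thin evidence, but it gives no reason to expect a step beyond the scatter in this assay, in either direction. The expected step is a 1.1-fold lower number from compound 2 to compound 3 (0.03 log units; within the scatter). For compound 3 the estimated value is 45000 nM, with an expected range of 20000 nM to 90000 nM.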

Compound 3, half-maximal inhibitory concentration: 3700 nM
The estimate for compound 3 lay 12-fold (1.09 log units) above the measured number; measured number outside the range, below it.
By their numbers in this assay, from the lowest: compound 3; then compounds 1 and 2 (each within the scatter of the next).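

In this assay, the group on a double-bonded chain carbon bound to a double-bonded chain carbon proves able to shift the number substantially: 2,3-dimethylphenyl in place of 2,6-dimethoxyphenyl gives (a 13-fold lower number from compound 2 to compound 3 (1.11 log units; beyond the scatter)), and 2,3-dimethylphenyl in place of isoquinolin-4-yl gives (a 12-fold lower number from compound 1 to compound 3 (1.09 log units; beyond the scatter)). Going by these compounds alone, the earlier pair had suggested a flat position, yet the two large steps show that the flatness held only for isoquinolin-4-yl and 2,6-dimethoxyphenyl, and both steps end at compound 3, the only compound here with 2,3-dimethylphenyl. Nothing available here explains why this group stands apart from the other two.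

The exchange from compound 2 to compound 3 alters both the kind of substituent and where the substituents sit, so the compounds shown do not separate the two. Going by these compounds, whether 2,3-dimethoxyphenyl or 2,6-dimethylphenyl would follow compound 3 or stay with compound 2, and where plain phenyl would fall, remains open.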